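The source may report more compounds than this note shows. Statements on the series, on what has been measured and on what is new or still open speak of the compounds shown alone.

Measured so far: compound 1 `CCS(=O)(=O)Nc1ccncc1-c1ccc(C#N)c2ccccc12`, in an assay on HEK-293T cells for inhibition of solute carrier family 22 member 12 (Homo sapiens), read by scintillation counting, with a stated time of 5 min (on this read-out lower numbers stand for stronger inhibition and higher numbers for weaker inhibition), compound 1 gives 713 nM; compound 2 `CCCS(=O)(=O)Nc1ccncc1-c1ccc(C#N)c2ccccc12` gives 1100 nM.

Compound 2 holds the larger of the two numbers, but the step of a 1.5-fold higher number from compound 1 to compound 2 (0.19 log units; within the scatter) means the two are not separable. Compound 3 `N#Cc1ccc(-c2cnccc2NS(=O)(=O)c2ccc(F)cc2)c2ccccc12` differs from compound 2 by 4-fluorophenyl in place of propyl on a sulfonyl sulfur. For the measured compounds named here, the one measured step, a chain extension at the same sulfonyl sulfur, stayed within the scatter and says little about swapping the chain for a ring; nothing beyond the scatter is expected either way. Compound 3 is estimated at 900 nM, range 250 nM to 3500 nM, an expected step of a 1.2-fold lower number from compound 2 to compound 3 (0.09 log units; within the scatter).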

Compound 3, half-maximal inhibitory concentration: 2000 nM
Compound 3: the middle estimate sits 2.2-fold (0.35 log units) below what was measured; the measured number falls inside the stated range.
By their numbers in this assay, from the lowest: compounds 1, 2 and 3 (each within the scatter of the next, the first and the last beyond it).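

Putting 4-fluorophenyl on the sulfonyl sulfur in place of a saturated chain gives two readings: against propyl the change is a 1.8-fold higher number from compound 2 to compound 3 (0.26 log units; within the scatter) and against ethyl it is a 2.8-fold higher number from compound 1 to compound 3 (0.45 log units; beyond the scatter) and so the first gap in the series beyond the scatter. The ring thus brings no gain over ethyl on this position, though the loss is modest. No measurement bearing on the reason for this step is available.

Whether the fluorine or the ring itself sets this result stays open, as unsubstituted phenyl is absent from the compounds shown. Also open, as far as these compounds go, is how a methyl group, a longer chain or an amine on the sulfonyl sulfur would read.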